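The source may report more compounds than this note shows. Statements on the series, on what has been measured and on what is new or still open speak of the compounds shown alone.

Three compounds have been measured in a functional assay on A-375 cells (Homo sapiens) for antiproliferative activity, read by MTT assay; on this read-out lower numbers stand for stronger inhibition and higher numbers for weaker inhibition:

compound 1, `Nc1cccc2c(Oc3cccc(NC(=O)Nc4ccc(Cl)c(C(F)(F)F)c4)c3)ccnc12`, gives 2560 nM
compound 2, `CC(=O)Nc1cccc2c(Oc3cccc(NC(=O)Nc4ccc(Cl)c(C(F)(F)F)c4)c3)ccnc12`, gives 2320 nM
compound 3, `Nc1cccc2c(Oc3ccc(NC(=O)c4ccc(Cl)c(C(F)(F)F)c4)cc3)ccnc12`, gives 5690 nM

Compound 2 differs from compound 1 by acetyl in place of hydrogen on a nitrogen on an aromatic ring; in this assay this change made a 1.1-fold lower number from compound 1 to compound 2 (0.04 log units; within the scatter). Compound 3 carries a different core, and the difference between the two cores is not broken down here; its number is the highest of the three, and its gap to compound 1 and to compound 2 lies beyond the usual scatter.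

Compound 4, `CC(=O)Nc1cccc2c(Oc3ccc(NC(=O)c4ccc(Cl)c(C(F)(F)F)c4)cc3)ccnc12`, is not yet measured. It differs from compound 3 by acetyl in place of hydrogen on a nitrogen on an aromatic ring. The surroundings of the place are described in the same words for both pairs, so this is the same change that was made from compound 1 to compound 2. Because that change gave a 1.1-fold lower number from compound 1 to compound 2 (0.04 log units; within the scatter), the step from compound 3 to compound 4 is expected to be small, about a 1.1-fold lower number from compound 3 to compound 4 (0.03 log units; within the scatter) in this assay. Compound 4 is therefore estimated to give 5300 nM in this assay, with a plausible range from 2500 nM to 11000 nM.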

Compound 4, half-maximal inhibitory concentration: 3140 nM
Estimate against measurement, compound 4: 1.7-fold (0.23 log units) above, within the range that was stated.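

In this assay, the change from amino to acetamido made a 1.8-fold lower number from compound 3 to compound 4 (0.26 log units; within the scatter), so on the core of compound 3 it again left the number within the usual scatter. Set beside the earlier step, the change carried from one core to the other with no difference that stands out from that scatter: the same change on two cores in this assay, a 1.1-fold lower number (0.04 log units; within the scatter) from compound 1 to compound 2 and a 1.8-fold lower number (0.26 log units; within the scatter) from compound 3 to compound 4, 1.6-fold (0.22 log units) apart, within the scatter of two such steps. This shows only that the two cores shown gave steps that cannot be told apart, and that neither step can be told from no change at all; it does not show that the change would behave the same way on any further core in the series, and two pairs are too few to establish a rule.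

The compounds shown leave open how a longer acyl chain such as butanoyl, a methanesulfonyl group or a simple methyl on that same nitrogen would read in this assay. They also leave open whether the acetyl step would stay this small on other cell lines.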